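This account rests on a few compounds, and the source may have more. Where it says the series, first, only, none or still open, it means among the compounds named here.

Values in a functional assay on C6 cells (Rattus norvegicus) for inhibition, read by sulforhodamine B assay, with a stated time of 72 h; on this read-out lower numbers stand for an effect already at smaller amounts and higher numbers for an effect only at larger amounts of compound:
- Compound 1 `CCCCc1ccc(C(=O)/C=C/c2ccc([N+](=O)[O-])o2)cc1`: 1700 nM
- Compound 2 `O=C(/C=C/c1ccc([N+](=O)[O-])o1)c1ccc(-n2ccnc2)cc1`: 3500 nM

Going by the values given here, compound 2 has the higher of the two numbers in this assay, and compound 1 is its only neighbour. The next compound, compound 3 `O=C(/C=C/c1ccc([N+](=O)[O-])o1)c1ccc(C2CCCCC2)cc1`, has not yet been measured. It carries cyclohexyl in place of 1H-imidazol-1-yl on an aromatic carbon, para to a large group: cyclohexyl in place of 1H-imidazol-1-yl on an aromatic carbon.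

Among the compounds with values here, only one measured step bears on this change: a 2.1-fold higher number from compound 1 to compound 2 (0.31 log units; beyond the scatter). That step is modest, though beyond the scatter, and it came with 1H-imidazol-1-yl replacing butyl. The change to compound 3 removes the same group, so a shift of similar size in the opposite direction, towards a lower number, is expected. Within the data shown here, this rests on a single pair, and no cyclohexyl compound has a measured value yet, so the expectation is loose.

The estimated change is a 1.9-fold lower number from compound 2 to compound 3 (0.29 log units; within the scatter). For compound 3 the expected value is 1800 nM, with an estimated range of 600 nM to 5000 nM.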

Compound 3, half-maximal effective concentration: 5100 nM
Compound 3: the middle estimate sits 2.8-fold (0.45 log units) below what was measured, outside the stated range (above it).
By their numbers in this assay, from the lowest: compound 1; then compounds 2 and 3 (each within the scatter of the next).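

In this assay, a 1.5-fold higher number from compound 2 to compound 3 (0.16 log units; within the scatter), so on this aromatic carbon, para to a large group, 1H-imidazol-1-yl and cyclohexyl cannot be told apart, even though one is a five-membered aromatic ring with 2 hetero atoms and 2 hydrogen-bond acceptors and the other a six-membered non-aromatic ring of carbon only with 0 hydrogen-bond acceptors. Butyl now stands apart from both ring groups, with a 3.0-fold higher number from compound 1 to compound 3 (0.48 log units; beyond the scatter) alongside a 2.1-fold higher number from compound 1 to compound 2 (0.31 log units; beyond the scatter), which makes compound 1 the lowest of the three on steps beyond the scatter, although both steps remain modest and rest on this one compound. No measurement at hand accounts for the separation of butyl from the two ring groups.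

The compounds shown leave open whether the lower number of compound 1 belongs to butyl alone or extends to open chains in general, which a longer chain such as hexyl or a shorter one such as ethyl at this place would address. They also leave open how an amine or a carboxylic acid on this aromatic carbon would compare with the three groups.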